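The source may hold more compounds than are shown below. What is called first, only, known or untested is meant among the compounds shown, and "the series" means these compounds.

Measured so far:
compound 1 `O=C(C1CCC(F)(F)CC1)N1CC(c2nc(-c3cccc(Cl)c3)no2)C1`, in an assay on HEK293 cells for positive allosteric modulation of metabotropic glutamate receptor 5 (Homo sapiens), read by FLIPR (on this read-out higher numbers stand for an effect only at larger amounts of compound and lower numbers for an effect already at smaller amounts), 180 nM
compound 2 `O=C(c1ccccc1F)N1CC(c2nc(-c3cccc(Cl)c3)no2)C1`, in this assay > 10000 nM

Compound 2 stands at the weak end of this pair. In this assay compound 2 gives only a limit, > 10000 nM, and no number; this is the limit of > 10000 nM in this assay, at which 1 of the 2 values shown sits. Compound 3 `O=C([C@@H]1CC2CCC1C2)N1CC(c2nc(-c3cccc(Cl)c3)no2)C1` differs from compound 2 in one place: a group of 7 heavy atoms (7 carbon; 2 five-membered non-aromatic rings of carbon only) in place of a group of 7 heavy atoms (6 carbon, 1 fluorine; one six-membered aromatic ring of carbon only), on a carbonyl carbon.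

Among the compounds with values here, one measured step bears on this change. an at least 55-fold higher number from compound 1 to compound 2 (1.74 log units; beyond the scatter), and that step ran in the opposite direction, a saturated ring on the carbonyl carbon giving way to the 2-fluorophenyl. The change to compound 3 undoes that swap in kind, though with two five-membered non-aromatic rings entering rather than the 4,4-difluorocyclohexyl of compound 1. A large step back towards smaller numbers is therefore expected, an at least 25-fold lower number from compound 2 to compound 3 (1.39 log units; beyond the scatter), while the different saturated ring leaves room for the value to land somewhat either side of compound 1. Compound 3 is estimated at 400 nM, within a range of 100 nM to 3000 nM.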

Compound 3, half-maximal effective concentration: 98 nM
Compound 3: middle estimate off by 4.1-fold (0.61 log units), on the high side; the whole stated range lies above it.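

In this assay, the second group with non-aromatic rings on the carbonyl carbon again gives a measurable effect where the 2-fluorophenyl does not, with an at least 100-fold lower number from compound 2 to compound 3 (2.00 log units; beyond the scatter). The gap between the two saturated groups is small, with a 1.8-fold lower number from compound 1 to compound 3 (0.26 log units; within the scatter), so this read-out does not separate the 4,4-difluorocyclohexyl from the carbon-only group with its 2 five-membered non-aromatic rings, and the fluorines of compound 1 are shown not to be required at this place, since compound 3 carries none. For compound 2 the value is a limit and not a number, so the step from it gives only a bound: the limit of > 10000 nM in this assay, at which 1 of the 3 values shown sits.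

The compounds shown leave open whether the loss in compound 2 belongs to the aromatic ring itself or to its fluorine, which a plain phenyl on the same carbonyl carbon would separate, and whether a ring is needed at all, which an open chain such as tert-butyl would test. They also leave open how much the defined stereocentre of compound 3 matters, and whether a nitrogen-containing ring such as piperidine would be accepted at this place.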